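The compounds below may be only part of what the source reports. "The series", "measured", "known", "first", "only" and "open" are said of these compounds alone.

Three closely related compounds have been tested in a functional assay on Huh-7 cells (Homo sapiens) for inhibition, read by MTT assay, with a stated time of 48 h (on this read-out higher numbers stand for weaker inhibition and lower numbers for stronger inhibition), and all three stop at the same edge of what the method can report.

Compound 1 has the structure `Cc1nnsc1CO/N=C/c1c(C)nn(C)c1Oc1ccc(OC(F)(F)F)cc1`. In this assay compound 1 gives > 50000 nM, which is a limit of the method rather than a measured number.

Compound 2, `CCc1nnsc1CO/N=C/c1c(C)nn(C)c1Oc1ccc(OC(F)(F)F)cc1`, is built from compound 1 by one change: methyl in place of hydrogen on a saturated chain carbon bound to an aromatic carbon. In this assay compound 2 gives > 50000 nM, again a limit. The step for this change is a step that the two limits leave unreadable from compound 1 to compound 2; both ends rest on (the limit of > 50000 nM in this assay, at which 3 of the 3 values shown sit), so the change cannot be sized.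

Compound 3 has the structure `CCc1nnsc1CO/N=C/c1c(C)nn(C)c1Cl`. In this assay compound 3 gives > 50000 nM, once more a limit. How the core of compound 3 differs from the core of compound 1 is not broken down here.

Compound 4, `CCCc1nnsc1CO/N=C/c1c(C)nn(C)c1Cl`, has not been measured. It differs from compound 3 by methyl in place of hydrogen on a saturated chain carbon, two bonds along the chain from an aromatic carbon. Among the measured compounds shown here, this is the same kind of change as the one from compound 1 to compound 2, but at a different place: there the new methyl sits on a saturated chain carbon bound to an aromatic carbon, here on a saturated chain carbon two bonds along the chain from an aromatic carbon.

For the measured compounds named here, for compound 4 the expected step is a step that the limit leaves unreadable from compound 3 to compound 4, since the earlier step that the two limits leave unreadable from compound 1 to compound 2 showed no readable movement and every value so far sits at the limit of > 50000 nM in this assay, at which 3 of the 3 values shown sit. Compound 4 is therefore estimated at 100000 nM, expected to fall between 30000 nM and 500000 nM, most likely reported only as a limit.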

Compound 4, half-maximal inhibitory concentration: > 50000 nM
Compound 4 ended at the assay's limit; the forecaster's own chance of this, stated with the estimate: 85%; the middle value does not contradict the limit.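

The step from compound 3 to compound 4 cannot be read, and it adds no size to the picture, since both compounds stop at a limit of the method rather than at a measured number: the limit of > 50000 nM in this assay, at which 4 of the 4 values shown sit.

The compounds shown leave open which change to the chain or the shared core, if any, would bring a measured value within reach of this assay at all.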